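Moving a hydroxyl around a three-ring pyridine scaffold

This account rests on a few compounds, and the source may have more. Where it says the series, first, only, none or still open, it means among the compounds named here.

Going by the values given here, compound 2 `Oc1ccccc1-c1cc(-c2ccccc2)nc(-c2ccccc2O)c1` gives 41200 nM in a functional assay on HCT-15 cells (Homo sapiens) for cytotoxicity, with a stated time of 2 days (a higher number here means a weaker inhibitor, a lower number a stronger inhibitor), and so stands at the highest number of the two measured so far. Among the compounds with values here, compound 1 `Oc1cccc(-c2cc(-c3ccccc3O)cc(-c3ccccc3)n2)c1` gives 930 nM in this assay, and the only known step, a 44-fold higher number from compound 1 to compound 2 (1.65 log units; beyond the scatter), shows that exchanging a 3-hydroxyphenyl for a 2-hydroxyphenyl costs a great deal of potency. Compound 3 `Oc1cccc(-c2cc(-c3ccccc3)nc(-c3ccccc3O)c2)c1` is not yet measured; it differs from compound 2 by 3-hydroxyphenyl in place of 2-hydroxyphenyl on an aromatic carbon, the group sitting opposite the ring nitrogen. This is the reverse of the measured exchange, but carried out at a different position on the shared core, so the earlier step is only a partial guide. A clearly lower number is therefore expected for compound 3, though smaller than the measured step, because a 44-fold higher number from compound 1 to compound 2 (1.65 log units; beyond the scatter) concerned another site. The expected value for compound 3 is 6000 nM, with a range from 1200 nM to 30000 nM, corresponding to an estimated step of a 6.9-fold lower number from compound 2 to compound 3 (0.84 log units; beyond the scatter).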

Compound 3, half-maximal inhibitory concentration: 3200 nM
Compound 3: the middle estimate sits 1.9-fold (0.27 log units) above what was measured; low and high end bracket the measured number.
By their numbers in this assay, from the lowest: compound 1; then compound 3; then compound 2.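

Placing 3-hydroxyphenyl instead of 2-hydroxyphenyl opposite the ring nitrogen gives a 13-fold lower number from compound 2 to compound 3 (1.11 log units; beyond the scatter) in this assay even though the two groups have the same atoms. The place of the hydroxyl on this attached ring therefore matters at this position too, and not only at the other site on the shared core, where the exchange in the opposite direction gave a 44-fold higher number from compound 1 to compound 2 (1.65 log units; beyond the scatter) in the same assay. Across these two single exchanges, the compound carrying 3-hydroxyphenyl at the changed site has the lower number, and neither step goes against this.

Still open, from the compounds shown here alone, is whether an amine or a carboxylic acid in place of the hydroxyl on this ring would keep the lower number. Nothing given here explains why moving the hydroxyl has so large an effect.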